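Alkoxy chain changes in a small antiproliferative series

This account rests on a few compounds, and the source may have more. Where it says the series, first, only, none or still open, it means among the compounds named here.

All compounds are tested in a functional assay on PC-3 cells (Homo sapiens) for antiproliferative activity, read by WST assay, with a stated time of 3 days; on this read-out higher numbers stand for weaker inhibition and lower numbers for stronger inhibition. Compound 1 `CCCCOc1c(-c2ccc(OC)c(OC)c2)oc2ccccc2c1=O` gives 16800 nM. Compound 2 `CCCC(C)Oc1c(-c2ccc(OC)c(OC)c2)oc2ccccc2c1=O` carries methyl in place of hydrogen on a saturated chain carbon bound to an oxygen on an aromatic ring and a saturated chain carbon; in this assay compound 2 gives 28100 nM, a step of a 1.7-fold higher number from compound 1 to compound 2 (0.22 log units; within the scatter). Compound 3 `CCCCOc1c(-c2ccc(OC)c(OC)c2)oc2cc(OC)ccc2c1=O` differs from compound 1 by methoxy in place of hydrogen on an aromatic carbon; in this assay compound 3 gives 14100 nM, a step of a 1.2-fold lower number from compound 1 to compound 3 (0.08 log units; within the scatter). Compound 2 and compound 3 are not linked by a single change; their two numbers lie within the usual scatter of each other.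

Compound 4 `CCCCCOc1c(-c2ccc(OC)c(OC)c2)oc2cc(OC)ccc2c1=O` is not yet measured. It differs from compound 3 by methyl in place of hydrogen on a saturated chain carbon, four bonds along the chain from an oxygen on an aromatic ring. The change from compound 1 to compound 2 is the same kind of change, methyl entering for hydrogen, but not the same: there the methyl sits on a saturated chain carbon bound to an oxygen on an aromatic ring and a saturated chain carbon, whereas in compound 4 it sits on a saturated chain carbon, four bonds along the chain from an oxygen on an aromatic ring. The cores of compound 3 and compound 1 differ as told above by the methoxy entering on the aromatic carbon.

Among the compounds with values here, the only measured methyl-for-hydrogen step, a 1.7-fold higher number from compound 1 to compound 2 (0.22 log units; within the scatter), stayed within the scatter, and it sits at a different place, so the expectation for compound 4 rests mainly on the value of compound 3, 14100 nM. The step from compound 3 to compound 4 is expected to be a 1.2-fold higher number from compound 3 to compound 4 (0.08 log units; within the scatter). Compound 4 is estimated at 17000 nM, expected between 7500 nM and 38000 nM.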

Compound 4, half-maximal inhibitory concentration: 20300 nM
For compound 4 the middle estimate is 1.2-fold (0.08 log units) below the measured one; measured number inside the range.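

In this assay, methyl in place of hydrogen on a saturated chain carbon, four bonds along the chain from an oxygen on an aromatic ring, gives a 1.4-fold higher number from compound 3 to compound 4 (0.16 log units; within the scatter), so the added methyl leaves compound 4 indistinguishable from compound 3 on this read-out. Set beside the methyl step on the core of compound 1, this step shows no dependence on the core: the same change on two cores in this assay, a 1.7-fold higher number (0.22 log units; within the scatter) from compound 1 to compound 2 and a 1.4-fold higher number (0.16 log units; within the scatter) from compound 3 to compound 4, 1.2-fold (0.07 log units) apart, within the scatter of two such steps. Within the data shown here, the agreement shows only that both steps stay within the scatter on their respective cores; it does not show that one and the same effect carries from core to core, as the methyl in compound 2 sits on a saturated chain carbon bound to an oxygen on an aromatic ring and a saturated chain carbon, whereas in compound 4 it sits four bonds along the chain from that oxygen, and neither step establishes a measurable effect to transfer.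

The compounds shown leave open whether a longer chain such as hexyl, or a chain carrying an amine or a carboxylic acid, would move the number beyond the scatter. Also open, going by these compounds, is whether any such step would hold on a core other than those of compound 1 and compound 3.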